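Removing one methoxy from the aryl ketone of compound 3

The compounds below may be only part of what the source reports. "The series", "measured", "known", "first", "only" and "open" are said of these compounds alone.

Compound 1, `COc1cc(-c2cc(/C=C/C(=O)c3ccc(N)cc3)[nH]n2)cc(OC)c1OC`, in a functional assay on IGROV-1 cells (Homo sapiens) for inhibition, read by sulforhodamine B assay, with a stated time of 48 h (on this read-out lower numbers stand for stronger inhibition of growth and higher numbers for weaker inhibition of growth), gives 3200 nM.
Compound 2, `COc1cc(-c2cc(/C=C/C(=O)c3ccc(Cl)c(Cl)c3)[nH]n2)cc(OC)c1OC`, in this assay gives 24000 nM.
Compound 3, `COc1ccc(C(=O)/C=C/c2cc(-c3cc(OC)c(OC)c(OC)c3)n[nH]2)cc1OC`, in this assay gives 1800 nM.

Compound 3 has the lowest of the three numbers in this assay. Its gap to compound 1, a 1.8-fold lower number from compound 1 to compound 3 (0.25 log units; within the scatter), lies within the scatter, so the two cannot be ranked; only its gap to compound 2, a 13-fold lower number from compound 2 to compound 3 (1.12 log units; beyond the scatter), is a clear separation.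

Compound 4, `COc1ccc(C(=O)/C=C/c2cc(-c3cc(OC)c(OC)c(OC)c3)n[nH]2)cc1`, differs from compound 3 by hydrogen in place of methoxy on an aromatic carbon, on the aromatic ring attached to the carbonyl carbon, ortho to a methoxy group and meta to a large group.

The measured steps that touch this ring all exchange the whole aryl group: a 1.8-fold lower number from compound 1 to compound 3 (0.25 log units; within the scatter) was small, while a 7.5-fold higher number from compound 1 to compound 2 (0.88 log units; beyond the scatter) and a 13-fold lower number from compound 2 to compound 3 (1.12 log units; beyond the scatter) were larger. Among the compounds with values here, none of them removes a single methoxy, so no direct precedent exists. Since compound 1 and compound 3, which carry quite different groups on this ring, differ only within the scatter, a change of one methoxy is expected to move the number little, if at all, with at most a modest weakening. Compound 4 is therefore expected to give 2500 nM, within 1000 nM to 7000 nM, a step of a 1.4-fold higher number from compound 3 to compound 4 (0.14 log units; within the scatter).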

Compound 4, concentration for 50% growth inhibition: 2210 nM
For compound 4 the middle estimate is 1.1-fold (0.05 log units) above the measured one; the measured number falls inside the stated range.
By their numbers in this assay, from the lowest: compounds 3, 4 and 1 (each within the scatter of the next); then compound 2.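

In this assay, the change from 3,4-dimethoxyphenyl to 4-methoxyphenyl gives a 1.2-fold higher number from compound 3 to compound 4 (0.09 log units; within the scatter) and so shows that the methoxy ortho to a methoxy group and meta to a large group can be replaced by hydrogen without a change that stands out from the scatter. Methoxy in place of amino on the same ring gives a 1.4-fold lower number from compound 1 to compound 4 (0.16 log units; within the scatter) as well, so the aryl ketones of compound 1, compound 3 and compound 4 cannot be ranked in this assay. Within the data shown here, the separation from the 3,4-dichlorophenyl group survives with only one methoxy on the ring, as an 11-fold lower number from compound 2 to compound 4 (1.04 log units; beyond the scatter) shows, and compound 2 thus remains the only compound here that stands apart from the others.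

No supporting data are available to explain these results. The compounds shown leave open whether the remaining methoxy matters at all, as a plain phenyl, a hydroxyl or an ethoxy in its place would test, and whether one chlorine alone would give a number like that of compound 2.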